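Adding an Amino Group to a Dichloro-Free Purine Core

The source may hold more compounds than are shown below. What is called first, only, known or untested is meant among the compounds shown, and "the series" means these compounds.

Compound 3 `ClCc1ccccc1Cn1cnc2c(Cl)ncnc21` gives the highest number among the three measured compounds in a functional assay on TK-10 cells (Homo sapiens) for cytotoxicity, read by sulforhodamine B assay, with a stated time of 48 h (on this read-out lower numbers stand for stronger inhibition of growth and higher numbers for weaker inhibition of growth), at 46800 nM. Compound 2 `Nc1nc(Cl)c2ncn(Cc3ccc(CCl)cc3)c2n1` lies within the scatter of it, with 40700 nM. For the measured compounds named here, compound 1 `ClCc1ccccc1Cn1cnc2c(Cl)nc(Cl)nc21` stands furthest away, at 2880 nM; the only recorded step, a 16-fold higher number from compound 1 to compound 3 (1.21 log units; beyond the scatter), concerns a chloro group and not the change now in question. The new compound 4 `Nc1nc(Cl)c2ncn(Cc3ccccc3CCl)c2n1` differs from compound 3 by amino in place of hydrogen on an aromatic carbon. Going by the values given here, no measured step tracks this addition directly, though compound 2, which carries the same amino group, gives a number close to compound 3. The expectation is therefore a 1.2-fold lower number from compound 3 to compound 4 (0.07 log units; within the scatter), with compound 4 estimated at 40000 nM, between 15000 nM and 110000 nM.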

Compound 4, concentration for total growth inhibition: 36300 nM
Compound 4: the middle estimate sits 1.1-fold (0.04 log units) above what was measured; low and high end bracket the measured number.
By their numbers in this assay, from the lowest: compound 1; then compounds 4, 2 and 3 (each within the scatter of the next).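

At this carbon between two ring nitrogen atoms, amino and hydrogen cannot be told apart in this assay (a 1.3-fold lower number from compound 3 to compound 4 (0.11 log units; within the scatter)). Amino in place of chloro at the same carbon gives a large step (a 13-fold higher number from compound 1 to compound 4 (1.10 log units; beyond the scatter)), so among compounds 1, 3 and 4, only the chloro of compound 1 goes with a clearly lower number. No evidence given here explains this.

Still open, going by these compounds, is whether a bromo, methoxy or methylamino group at this carbon would behave like chloro or like amino and hydrogen.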